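This account rests on a few compounds, and the source may have more. Where it says the series, first, only, none or still open, it means among the compounds named here.

Measured so far in a functional assay on L1210 cells (Mus musculus), with a stated time of 12 days; on this read-out higher numbers stand for higher potency (the scale is a negative logarithm) and lower numbers for lower potency:
compound 1 `CC1=C(N2CC2)C(=O)C(CC(C)OC(N)=O)=C(N2CC2)C1=O` gives 6.14
compound 2 `CCOC(COC(N)=O)C1=C(N2CC2)C(=O)C(C)=C(N2CC2)C1=O` gives 6.18
compound 3 `COCCC1=C(N2CC2)C(=O)C(CCOC)=C(N2CC2)C1=O` gives 5.69

Among these three numbers compound 1 stands second highest. Its nearest neighbour is compound 2, whose value lies within the scatter of it, so the two cannot be ordered; its furthest is compound 3, whose value lies beyond the scatter below it. Both compound 1 and compound 2 carry a side group with a hydrogen-bond donor and two hydrogen-bond acceptors, whereas compound 3 carries none, and compound 3 is the one that falls behind.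

Compound 4 `CC1=C(N2CC2)C(=O)C(C2CCCCC2)=C(N2CC2)C1=O` has not been measured in this assay. It departs from compound 1 in one place: a group of 6 heavy atoms (6 carbon; one six-membered non-aromatic ring of carbon only) in place of a group of 7 heavy atoms (4 carbon, 1 nitrogen, 2 oxygen; no ring), on a double-bonded ring carbon. Cyclohexyl brings no hydrogen-bond donor and no acceptor, and the group that leaves carried both.

Among the compounds with values here, no direct step between measured compounds is available to calibrate this change. On the showing of compound 3 with its value of 5.69, the loss of the donor and acceptors is expected to cost potency in this assay, by a step of moderate size, beyond the scatter but not large. The estimated step from compound 1 to compound 4 is a number 0.44 log units lower from compound 1 to compound 4 (beyond the scatter). Compound 4 is therefore expected to give about 5.7, with a range from 5.2 to 6.2.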

Compound 4, logarithm of the reciprocal of the active concentration, log(1/C): 5.82
The estimate for compound 4 lay 0.12 log units below the measured number; the measured number falls inside the stated range.
By their numbers in this assay, from the lowest: compounds 3 and 4 (each within the scatter of the next); then compounds 1 and 2 (each within the scatter of the next).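

At the double-bonded ring carbon next to the ring atom that bears an aziridin-1-yl group, exchanging the group of 7 heavy atoms for cyclohexyl now has a direct reading in this assay as a number 0.32 log units lower from compound 1 to compound 4 (beyond the scatter) and so counts as a modest step. The donor and acceptors of the group that leaves are therefore not needed for activity on this read-out, since compound 4 gives 5.82 with a ring of carbon only at this place, although the step shows that the exchange does carry a real cost. No measurement shown here offers an explanation for this step.

The donor and acceptors leave and the ring enters in the same exchange, so the compounds shown cannot separate the contribution of each. Open too, from the compounds shown here alone, is how this position would respond to an open hexyl chain with no ring, to a phenyl ring, or to a simple aminoethyl or hydroxyethyl chain, any of which would help to tell the two contributions apart.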